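Series notes: cyano for trifluoromethyl on the ring-nitrogen aryl

The compounds below may be only part of what the source reports. "The series", "measured", "known", "first", "only" and "open" are said of these compounds alone.

Measured so far in an assay on isolated protein for inhibition of Ephrin type-A receptor 2 (Homo sapiens), read by thermal shift assay, tested at 10 uM; on this read-out lower numbers stand for weaker stabilisation of the target and higher numbers for stronger stabilisation of the target against heat:
- compound 1 `CC(C)(C)c1cc(NC(=O)Nc2cc(F)cc(F)c2)n(C(C)(C)C)n1` gives 0 degrees C
- compound 2 `CC(C)(C)c1cc(NC(=O)Nc2cc(F)cc(F)c2)n(-c2ccc(Br)cc2)n1` gives 1.3 degrees C
- compound 3 `CC(C)(C)c1cc(NC(=O)Nc2ccc(Cl)cc2)n(-c2ccc(C(F)(F)F)cc2)n1` gives 0.6 degrees C

Compound 3 stands second highest of the three numbers; its gap to compound 1 and its gap to compound 2 both lie within the scatter, so no order among these three is read from it. Going by the values given here, the only step measured in one place is a number 1.3 degrees C higher from compound 1 to compound 2 (beyond the scatter), a modest rise beyond the scatter when the group on the aromatic nitrogen is enlarged.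

Compound 4 `CC(C)(C)c1cc(NC(=O)Nc2ccc(Cl)cc2)n(-c2ccc(C#N)cc2)n1` differs from compound 3 by cyano in place of trifluoromethyl on an aromatic carbon. Among the compounds with values here, no measured pair changes the group that sits para to a large group on this aryl, so no step bears directly on it. Compound 2 and compound 3 carry different groups there, but they also differ at the urea aryl, and their values lie within the scatter of each other, which gives no lean either way. The expectation for compound 4 is therefore no step beyond the scatter, estimated as a number 0.10 degrees C higher from compound 3 to compound 4 (within the scatter). Compound 4 is expected to give about 0.7 degrees C in this assay, within a range of -0.5 degrees C to 1.9 degrees C.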

Compound 4, shift of the target's melting temperature: 0.8 degrees C
Compound 4: the middle estimate sits 0.10 degrees C below what was measured; low and high end bracket the measured number.
By their numbers in this assay, from the lowest: compounds 1, 3, 4 and 2 (each within the scatter of the next, the first and the last beyond it).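

In this assay, going by these compounds alone, cyano in place of trifluoromethyl on an aromatic carbon, para to a large group, gives a number 0.20 degrees C higher from compound 3 to compound 4 (within the scatter) and is the first step measured at this place on the aryl carried by the ring nitrogen. Four heavy atoms with no hydrogen-bond acceptor leave and two heavy atoms with one hydrogen-bond acceptor enter, yet this pair shows no difference that can be read beyond the scatter, so on this evidence the two groups cannot be told apart in this read-out. Nothing measured here accounts for that result.

On these data alone, it remains open whether an amine, a carboxylic acid or a longer chain at this same place would give a step beyond the scatter in this assay. It also remains open whether the exchange of cyano for trifluoromethyl would read the same way with the urea aryl of compound 2, since the pair shown here carries only the 4-chlorophenyl urea.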